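The source may report more compounds than this note shows. Statements on the series, on what has been measured and on what is new or still open speak of the compounds shown alone.

Compound 3, `N#CC1=C(N)Oc2c(c3nc4ccccc4nc3c3ccccc23)C12C(=O)N(Cc1cnnn1-c1ccc([N+](=O)[O-])cc1)c1ccccc12`, is the compound whose value in a functional assay on A549 cells (Homo sapiens) for antiproliferative activity, read by MTT assay, with a stated time of 48 h (a higher number here means a weaker inhibitor, a lower number a stronger inhibitor), is only a limit: compound 3 gives > 50000 nM. Compound 1, `N#CC1=C(N)Oc2c(c3nc4ccccc4nc3c3ccccc23)C12C(=O)N(Cc1cnnn1-c1ccccc1Cl)c1ccccc12`, gives 42600 nM in this assay. Compound 2, `N#CC1=C(N)Oc2c(c3nc4ccccc4nc3c3ccccc23)C12C(=O)N(Cc1cnnn1-c1ccccc1Br)c1ccccc12`, also sits at a limit in this assay, where compound 2 gives > 50000 nM. Compound 4, `Cc1ccc(Cl)cc1-n1nncc1CN1C(=O)C2(C(C#N)=C(N)Oc3c2c2nc4ccccc4nc2c2ccccc32)c2ccccc21`, differs from compound 3 by 5-chloro-2-methylphenyl in place of 4-nitrophenyl on an aromatic nitrogen. The nearest measured step is an at least 1.1-fold higher number from compound 1 to compound 3 (0.06 log units; that floor lies within the scatter); the neighbouring step an at least 1.1-fold higher number from compound 1 to compound 2 (0.06 log units; that floor lies within the scatter) likewise stays within the scatter, while a step that the two limits leave unreadable from compound 2 to compound 3. Since two of the three values sit at the limit of > 50000 nM in this assay, at which 2 of the 3 values shown sit, the change to 5-chloro-2-methylphenyl is expected to move the number little, and the step of an at least 1.1-fold lower number from compound 3 to compound 4 (0.04 log units; that floor lies within the scatter) is expected to be none beyond the scatter. Compound 4 is therefore estimated at 45000 nM, within 20000 nM to 100000 nM.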

Compound 4, half-maximal inhibitory concentration: > 50000 nM
Compound 4 was reported as a limit (the forecaster's own chance of this, stated with the estimate: 50%); at least 1.1-fold (0.04 log units) between middle value and limit.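

In this assay, 5-chloro-2-methylphenyl on this aromatic nitrogen does not bring the number clear of the assay limit, so a third substituted phenyl group behaves like those before it. Going by these compounds alone, the one readable new step is an at least 1.1-fold higher number from compound 1 to compound 4 (0.06 log units; that floor lies within the scatter), while the steps linking compound 4 to compound 2 and compound 3 cannot be read. The limit now holds most of the set: the limit of > 50000 nM in this assay, at which 3 of the 4 values shown sit.

As far as these compounds go, how far compound 2, compound 3 and compound 4 actually differ remains open. So does whether a benzyl group, a longer alkyl chain or an aminophenyl group on this nitrogen would bring the number clearly below the limit.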